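The source may report more compounds than this note shows. Statements on the series, on what has been measured and on what is new or still open speak of the compounds shown alone.

Series notes, step from compound 2 to compound 4.

In an ADME assay on HEK293 cells for agonist activity at metabotropic glutamate receptor 5 (Rattus norvegicus), read by fluorescence and calcium flux (a lower number here means a smaller maximal response, a higher number a larger maximal response), compound 2 `C[C@@H](NC(=O)c1ccc(C#Cc2cccnc2)cn1)C(C)(C)O` gives 25.9%. Its number is the highest of the three measured, but the gap to compound 1 `Cc1cccc(C#Cc2ccc(C(=O)N[C@H](C)C(C)(C)O)nc2)c1`, which gives 20.8%, is a number 5.1 percentage points higher from compound 1 to compound 2 (within the scatter) and so tells nothing of order. Compound 3 `C[C@@H](NC(=O)c1ccc(C#Cc2cccc(F)n2)cn1)C(C)(C)O` gives 8.3%, and the step of a number 17.6 percentage points lower from compound 2 to compound 3 (beyond the scatter) is the only one of the three that clearly separates two compounds.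

Compound 4 `C[C@@H](NC(=O)c1ccc(C#Cc2cc(F)ccn2)cn1)C(C)(C)O` differs from compound 2 as follows: 4-fluoropyridin-2-yl in place of pyridin-3-yl on a triple-bonded carbon.

Going by the values given here, two measured steps bear on this change, both putting a fluoropyridin-2-yl on the triple-bonded carbon: a number 17.6 percentage points lower from compound 2 to compound 3 (beyond the scatter) and a number 12.5 percentage points lower from compound 1 to compound 3 (beyond the scatter). Both point the same way and are of modest size. The fluorine in compound 4 sits at a different position of the pyridin-2-yl, so the size is not certain, but the direction is expected to match.

For compound 4 a step of a number 13.9 percentage points lower from compound 2 to compound 4 (beyond the scatter) is therefore expected in this assay, giving an estimated 12% with a range from 4% to 24%.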

Compound 4, largest response reached (reported as efficacy), in percent of the reference or control that the assay uses: 33%
Compound 4: the middle estimate sits 21 percentage points below what was measured, outside the stated range (above it).
By their numbers in this assay, from the lowest: compound 3; then compounds 1, 2 and 4 (each within the scatter of the next, the first and the last beyond it).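

In this assay, a fluoropyridin-2-yl on the triple-bonded carbon does not in itself go with a low number: 4-fluoropyridin-2-yl in place of 6-fluoropyridin-2-yl gives a number 24.7 percentage points higher from compound 3 to compound 4 (beyond the scatter), so the two fluorinated isomers are clearly separated. Against pyridin-3-yl the change gives a number 7.1 percentage points higher from compound 2 to compound 4 (within the scatter), which sets no order, whereas against 3-methylphenyl it gives a number 12.2 percentage points higher from compound 1 to compound 4 (beyond the scatter), even though compound 1 and compound 2 lie within the scatter of each other. No measurement at hand accounts for the separation between the two fluoropyridin-2-yl groups.

On these data alone, it remains open whether an unsubstituted pyridin-2-yl, or a pyridin-2-yl carrying chlorine or a methyl group instead of fluorine, would fall with compound 3 or with compound 4. Also open, as far as these compounds go, is how these numbers respond when the hydroxyl of the shared amide chain gives way to an amine or a carboxylic acid.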